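A few compounds are considered here, and "the series" means these few. Any claim that something is new, unique, unknown or untested is made for them only; others in the source may bear on it.

Compound 1, `CC(=O)OC/C(=C\C1CCCCC1)C(=O)c1ccccc1`, gives 21000 nM in a functional assay on HeLa cells (Homo sapiens) for inhibition, read by sulforhodamine B assay, with a stated time of 48 h; on this read-out higher numbers stand for weaker inhibition of growth and lower numbers for stronger inhibition of growth.
Compound 2, `C=C(C/C(=C\c1ccc(Cl)cc1)C(=O)c1ccccc1)C(=O)c1ccccc1`, gives 22000 nM in this assay.

Of the two numbers, that of compound 2 is nominally the higher, but the gap to compound 1 lies within the usual scatter, so no order can be read from it. For the measured compounds named here, no step between measured compounds has been worked out, so nothing here shows how a change at the ring position moves the numbers. Compound 3, `C=C(C/C(=C\c1ccc(OC)cc1)C(=O)c1ccccc1)C(=O)c1ccccc1`, differs from compound 2 in one place: methoxy in place of chloro on an aromatic carbon, on an aromatic carbon of a six-membered aromatic ring of carbon only, para to a large group. Going by the values given here, with no measured step to lean on, the step expected from this change is a 1.1-fold higher number from compound 2 to compound 3 (0.06 log units; within the scatter), that is, nothing beyond the scatter in either direction. Compound 3 is therefore estimated at 25000 nM, with a range from 10000 nM to 60000 nM.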

Compound 3, concentration for 50% growth inhibition: 320 nM
Compound 3: the middle estimate sits 78-fold (1.89 log units) above what was measured; measured number below the stated range.
By their numbers in this assay, from the lowest: compound 3; then compounds 1 and 2 (each within the scatter of the next).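

The swap of 4-chlorophenyl to 4-methoxyphenyl gives a 69-fold lower number from compound 2 to compound 3 (1.84 log units; beyond the scatter) in this assay and so shows that this place on the aromatic ring, para to a large group, is far from indifferent: one change here moves the number well beyond the scatter. For the compounds shown here, the two earlier compounds could not show this, since they offered no step at all. Nothing available here explains why methoxy and chloro part so widely. The compounds shown do not tell how a hydroxyl, an amine or a longer chain such as ethoxy would read at this place. From the compounds shown here alone, they also rest on a single step, so it remains open whether methoxy would bring a similar change on another core, such as that of compound 1.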